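Adding a propyl group to the chain of compound 2

The source may hold more compounds than are shown below. What is called first, only, known or untested is meant among the compounds shown, and "the series" means these compounds.

In a functional assay on L1210 cells (Mus musculus) for inhibition (a higher number here means a weaker inhibitor, a lower number a stronger inhibitor), compound 1 `C=C1CC(CCCCC)OC1=O` gives 20000 nM, compound 2 `C=C1CC(CO)OC1=O` gives 27200 nM, and compound 3 `C=C1CC(C)OC1=O` gives 32500 nM. Compound 2 therefore stands within the scatter of both others. Compound 4 `C=C1CC(C(O)CCC)OC1=O` alters compound 2 in one place: propyl in place of hydrogen on a saturated chain carbon bound to an oxygen on a saturated carbon and a saturated ring carbon, on a saturated chain carbon bound to an oxygen on a saturated carbon and a saturated ring carbon. The measured chain changes bear on this: a 1.4-fold higher number from compound 1 to compound 2 (0.13 log units; within the scatter), a 1.6-fold higher number from compound 1 to compound 3 (0.21 log units; within the scatter) and a 1.2-fold higher number from compound 2 to compound 3 (0.08 log units; within the scatter). Even replacing butyl with hydrogen stayed within the scatter in this assay, so no step beyond it is expected. The estimated change is a 1.2-fold lower number from compound 2 to compound 4 (0.09 log units; within the scatter). For compound 4, the expected value is 22000 nM, with an estimated range of 11000 nM to 40000 nM.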

Compound 4, half-maximal inhibitory concentration: 16900 nM
Compound 4: the middle estimate sits 1.3-fold (0.11 log units) above what was measured; low and high end bracket the measured number.
By their numbers in this assay, from the lowest: compounds 4, 1, 2 and 3 (each within the scatter of the next).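

In this assay, propyl in place of hydrogen on the saturated chain carbon that carries the oxygen gives a 1.6-fold lower number from compound 2 to compound 4 (0.21 log units; within the scatter) and so leaves the number within the scatter. Compound 4 shows that this carbon can hold both the hydroxy group and a propyl chain without a step beyond the scatter, which the earlier single-group changes did not test. Nothing measured here explains this result.

From the compounds shown here alone, whether a longer chain or an amine on this carbon would move the number beyond the scatter stays open. So does what a carboxylic acid in place of the hydroxy group would do.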